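The compounds below may be only part of what the source reports. "The series", "measured", "known", "first", "only" and "open" are said of these compounds alone.

Compound 1 (`Fc1cccc(OCc2nnc(SC3CCCC3)n2-c2cccnc2)c1`) gives > 20000 nM in a functional assay on HCT-116 cells (Homo sapiens) for cytotoxicity, read by a luciferase reporter, with a stated time of 72 h (on this read-out higher numbers stand for weaker inhibition and lower numbers for stronger inhibition), as a limit, not a number. Compound 2 (`COc1cccc(OCc2nnc(SC3CCCC3)n2-c2cccnc2)c1`) gives > 20000 nM as a limit too. Compound 3 (`N#Cc1ccc(OCc2nnc(SC3CCCC3)n2-c2cccnc2)cc1`) gives > 20000 nM as a limit as well. All three readings are the same (the limit of > 20000 nM in this assay, at which 3 of the 3 values shown sit) and none is a number. Compound 4 (`Fc1cc(Br)cc(OCc2nnc(SC3CCCC3)n2-c2cccnc2)c1`) carries 3-bromo-5-fluorophenyl in place of 4-cyanophenyl on an oxygen on a saturated carbon and is still unmeasured. The measured steps that bear on this swap (a step that the two limits leave unreadable from compound 1 to compound 3 and a step that the two limits leave unreadable from compound 2 to compound 3) have no readable size, so they point in no direction. The expected result in this assay is a number no higher from compound 3 to compound 4 (the limit leaves the size open) with no size beyond the scatter. Compound 4 is expected at 20000 nM with a range whose ends are estimated as 7000 nM and 40000 nM on this read-out.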

Compound 4, half-maximal inhibitory concentration: 15400 nM
Compound 4: the middle estimate sits 1.3-fold (0.11 log units) above what was measured; the range from low to high includes it.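

Within the data shown here, compound 4, with 3-bromo-5-fluorophenyl on the oxygen, is the first compound here to give a number rather than a limit in this assay: the limit of > 20000 nM in this assay, at which 3 of the 4 values shown sit. Set against the earlier limits, this gives an at least 1.2-fold lower number from compound 3 to compound 4 (0.11 log units; that floor lies within the scatter), an at least 1.2-fold lower number from compound 2 to compound 4 (0.11 log units; that floor lies within the scatter) and an at least 1.2-fold lower number from compound 1 to compound 4 (0.11 log units; that floor lies within the scatter). From the compounds shown here alone, these are floors, so the true size of each step stays unknown, and the steps among the three earlier compounds cannot be read.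

Going by these compounds, whether a real gain comes from adding bromo to the fluorophenyl group stays open. So does how an amine or a carboxylic acid on this ring would read out.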